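The source may report more compounds than this note shows. Statements on the series, on what has been measured and on what is new or still open speak of the compounds shown alone.

Measured compounds:
compound 1 `COc1cc(/C=C/C(=O)/C=C/c2cccs2)ccc1OCc1cn(CCOc2cc(=O)oc3ccccc23)nn1` gives 12%
compound 2 `COc1cc(/C=C/C(=O)/C=C/c2cc(OC)c(OC)c(OC)c2)ccc1OCc1cn(CCOc2cc(=O)oc3ccccc23)nn1` gives 22%
compound 3 `COc1cc(/C=C/C(=O)/C=C/c2cc(OC)c(OC)c(OC)c2)ccc1OCc1cn(CCCOc2cc(=O)oc3ccccc23)nn1` gives 12%

All three were run in a functional assay on PC-3 cells (Homo sapiens) for inhibition, read by sulforhodamine B assay, with a stated time of 48 h, tested at 50 uM; on this read-out higher numbers stand for more inhibition of growth at the one concentration tested and lower numbers for less inhibition of growth. Compound 2 and compound 1 share one core and differ only by thiophen-2-yl in place of 3,4,5-trimethoxyphenyl on a double-bonded chain carbon bound to a double-bonded chain carbon; the step is a number 10 percentage points lower from compound 2 to compound 1 (within the scatter). Compound 3 is built on a second core; how that core differs from the core of compound 2 is not broken down here. In this assay the three numbers all lie within the usual scatter of one another, so no ordering among them can be read from the data.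

Compound 4 `COc1cc(/C=C/C(=O)/C=C/c2cccs2)ccc1OCc1cn(CCCOc2cc(=O)oc3ccccc23)nn1` is the untested partner of compound 3 on the second core. Within the data shown here, it arises from compound 3 by thiophen-2-yl in place of 3,4,5-trimethoxyphenyl on a double-bonded chain carbon bound to a double-bonded chain carbon, which is the same change, at the same place, as the one from compound 2 to compound 1. Among the measured compounds shown here, the only guide to its size is the earlier step, which stayed within the scatter.

The step from compound 3 to compound 4 is expected to be a number 4 percentage points lower from compound 3 to compound 4 (within the scatter), because the matching step a number 10 percentage points lower from compound 2 to compound 1 (within the scatter) on the first core was small. Compound 4 is therefore estimated at 8% in this assay, with a range from -5% to 20%.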

Compound 4, percent growth inhibition at one concentration: "not active" (no number reported)
No number was reported for compound 4, and the estimate cannot be compared.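

In this assay, among these compounds, compound 4 is recorded as not active without a number, so no new step from compound 3 to compound 4 can be read. Nothing shown here bears on the reason for this result. The compounds shown leave open how thiophen-2-yl in place of 3,4,5-trimethoxyphenyl plays out on the second core.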